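The source may report more compounds than this note shows. Statements on the series, on what has been measured and on what is new or still open speak of the compounds shown alone.

Measured in a functional assay on DU-145 cells (Homo sapiens) for cytotoxicity, read by sulforhodamine B assay, with a stated time of 48 h; on this read-out lower numbers stand for stronger inhibition and higher numbers for weaker inhibition:
- compound 1 `C[C@H]1CC[C@@H]2[C@@H](OC(=O)[C@]23CC(c2ccc([N+](=O)[O-])cc2)=NO3)[C@]2(C)C(=O)C=C[C@@]12O`: 7000 nM
- compound 2 `COc1ccc(C2=NO[C@]3(C2)C(=O)O[C@@H]2[C@H]3CC[C@H](C)[C@]3(O)C=CC(=O)[C@@]23C)cc1OC`: 84000 nM
- compound 3 `C[C@H]1CC[C@@H]2[C@@H](OC(=O)[C@]23CC(c2ccccc2Cl)=NO3)[C@]2(C)C(=O)C=C[C@@]12O`: 19000 nM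

Compound 3 stands second highest of the three, with compound 1 lower and compound 2 higher. Compound 4 `Cc1cccc(C2=NO[C@]3(C2)C(=O)O[C@@H]2[C@H]3CC[C@H](C)[C@]3(O)C=CC(=O)[C@@]23C)c1` differs from it by 3-methylphenyl in place of 2-chlorophenyl on a carbon with a double bond to nitrogen. All measured aryl exchanges at this place went beyond the scatter: a 2.7-fold higher number from compound 1 to compound 3 (0.43 log units; beyond the scatter) and a 4.4-fold lower number from compound 2 to compound 3 (0.65 log units; beyond the scatter), both modest, and a 12-fold higher number from compound 1 to compound 2 (1.08 log units; beyond the scatter), large. Among the compounds with values here, no measured compound carries 3-methylphenyl, so the direction is uncertain. A small step in this assay is expected, leaning towards a higher number, and the estimated step is a 1.5-fold higher number from compound 3 to compound 4 (0.17 log units; within the scatter). For compound 4 the estimated value is 28000 nM, with an expected range of 10000 nM to 70000 nM.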

Compound 4, half-maximal inhibitory concentration: 28000 nM
Beside the measured number, compound 4's estimate shows no gap at the digits printed, within the range that was stated.
By their numbers in this assay, from the lowest: compound 1; then compounds 3 and 4 (each within the scatter of the next); then compound 2.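

In this assay, swapping 2-chlorophenyl for 3-methylphenyl at this place gives a 1.5-fold higher number from compound 3 to compound 4 (0.17 log units; within the scatter), so this exchange, unlike the earlier aryl exchanges, stays inside the scatter. The other two steps, a 3.0-fold lower number from compound 2 to compound 4 (0.48 log units; beyond the scatter) and a 4.0-fold higher number from compound 1 to compound 4 (0.60 log units; beyond the scatter), leave compound 1 with 4-nitrophenyl holding the lowest number of the four and compound 2 with 3,4-dimethoxyphenyl the highest. No evidence on hand accounts for these differences.

Still open, going by these compounds, is how an amine or a carboxylic acid on the phenyl ring would read here. Also open, on these data alone, is whether a longer alkyl chain could replace the aryl group at this carbon.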